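Formyl to ethoxycarbonyl at the limit of a cytotoxicity assay

The compounds below may be only part of what the source reports. "The series", "measured", "known", "first", "only" and "open" are said of these compounds alone.

Compound 1 `C=C[C@@](C)(/C=C/c1ccc(O)cc1)CCC1OC1(C)C` | > 49000 nM
Compound 2 `C=C[C@@](C)(/C=C/c1ccc(O)cc1)CC/C=C(\C)C=O` | > 49000 nM

Both entries come from a functional assay on Jurkat cells (Homo sapiens) for cytotoxicity, with a stated time of 72 h (on this read-out lower numbers stand for an effect already at smaller amounts and higher numbers for an effect only at larger amounts of compound), and both are limits, not numbers. Compound 2 stands at > 49000 nM, a limit of this assay, so its position is known only on one side. Compound 1 shares that position, and the record is simply (the limit of > 49000 nM in this assay, at which 2 of the 2 values shown sit).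

Compound 3 `C=C[C@@](C)(/C=C/c1ccc(O)cc1)CC/C=C(\C)C(=O)OCC` departs from compound 2 at one place: ethoxy in place of hydrogen on a carbonyl carbon. This is ethoxy in place of hydrogen on a carbonyl carbon, or formyl to ethoxycarbonyl when cut one bond further out.

Going by the values given here, the only measured step that bears on this change is a step that the two limits leave unreadable from compound 1 to compound 2, and it supplies no size to carry forward. Neither measured compound gives a number in this assay, so no step beyond the scatter is expected in either direction, and another limit is the likeliest report. The expected step is a number no higher from compound 2 to compound 3 (the limit leaves the size open) here. For compound 3 the estimated value is 49000 nM, within an expected range from 25000 nM to 100000 nM here.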

Compound 3, half-maximal effective concentration: > 49000 nM
Compound 3 gave a limit, no number (the forecaster's own chance of this, stated with the estimate: 80%); the middle value sits exactly at the limit.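

In this assay compound 3 gives > 49000 nM, which is a limit and not a number. Compound 2 also ends at a limit, so no step can be read between compound 2 and compound 3: the limit of > 49000 nM in this assay, at which 3 of the 3 values shown sit.

The compounds shown leave open whether ethoxy in place of hydrogen on a carbonyl carbon changes the cytotoxicity at all.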